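The source may report more compounds than this note shows. Statements on the series, on what has been measured and on what is new or still open speak of the compounds shown alone.

Working notes on the nucleoside series

Three compounds of a shared core have been run in a functional assay on CEM-DNR-bulk cells (Homo sapiens), read by MTT assay, with a stated time of 72 h; on this read-out higher numbers stand for weaker inhibition and lower numbers for stronger inhibition. Compound 3 `Cc1ncnc2c1c(-c1ccsc1)cn2[C@@H]1O[C@H](CO)[C@@H](O)[C@H]1O` gives 8560 nM. Compound 1 `Cc1ncnc2c1c(-c1ccoc1)cn2[C@@H]1O[C@H](CO)[C@@H](O)[C@H]1O` returns only a limit, > 20000 nM. Compound 2 `CNc1ncnc2c1c(-c1ccsc1)cn2[C@@H]1O[C@H](CO)[C@@H](O)[C@H]1O` likewise returns only a limit, > 20000 nM. The change from compound 3 to compound 1 is furan-3-yl in place of thiophen-3-yl on an aromatic carbon, and it produces an at least 2.3-fold higher number from compound 3 to compound 1 (0.36 log units; beyond the scatter). The two cores differ by methylamino in place of methyl on an aromatic carbon, and read in the measured direction this gives an at least 2.3-fold lower number from compound 2 to compound 3 (0.36 log units; beyond the scatter). Both changes away from compound 3 therefore carry the number up to the limit of > 20000 nM in this assay, at which 2 of the 3 values shown sit, so the true size of either step is not resolved.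

Compound 4 `CNc1ncnc2c1c(-c1ccoc1)cn2[C@@H]1O[C@H](CO)[C@@H](O)[C@H]1O` has not been measured. Among the compounds with values here, it differs from compound 2 by furan-3-yl in place of thiophen-3-yl on an aromatic carbon, the same change as the one from compound 3 to compound 1, with the place described in identical words, made here on the core of compound 2 rather than on that of compound 3. Compound 2 already sits at the limit of the assay, and the same change has only raised the number when made on the core of compound 3. A step that the limit leaves unreadable from compound 2 to compound 4 is expected, resting on an at least 2.3-fold higher number from compound 3 to compound 1 (0.36 log units; beyond the scatter) together with an at least 2.3-fold lower number from compound 2 to compound 3 (0.36 log units; beyond the scatter). Compound 4 is expected at 40000 nM, within 15000 nM to 150000 nM, and most probably it will be reported only as a limit.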

Compound 4, half-maximal inhibitory concentration: > 20000 nM
Compound 4 gave a limit, no number (the forecaster's own chance of this, stated with the estimate: 90%); the middle value does not contradict the limit.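

Compound 4 returns a limit, so its steps from compound 1 and from compound 2 each join two limits and neither can be read, because all three compounds stand at the same limit: the limit of > 20000 nM in this assay, at which 3 of the 4 values shown sit.

What the compounds shown leave open is how far compound 1 and compound 2 each truly lie from compound 3, and whether furan-3-yl in place of thiophen-3-yl shifts the number equally on both cores.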